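The source may hold more compounds than are shown below. What is called first, only, known or untested is meant among the compounds shown, and "the series" means these compounds.

Measured compounds and values:

Compound 1, `CCOC(=O)[C@@H]1CCC[C@@H](S(=O)(=O)c2ccc(S(=O)(=O)N(CC)CC)cc2)C1`, in a functional assay on BXPC-3 cells (Homo sapiens) for inhibition, read by MTT assay, with a stated time of 7 days (on this read-out lower numbers stand for stronger inhibition and higher numbers for weaker inhibition), compound 1 gives 18500 nM.
Compound 2, `CCOC(=O)[C@@H]1CCCN(S(=O)(=O)c2ccc(S(=O)(=O)N3CCOCC3)cc2)C1`, in this assay compound 2 gives 23400 nM.
Compound 3, `CCN(CC)S(=O)(=O)c1ccc(S(=O)(=O)N2CCC[C@@H](C(=O)N(C)C(C)C)C2)cc1`, in this assay compound 3 gives 7700 nM.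

Compound 3 has the lowest of the three numbers in this assay. Its gap to compound 1 is the smaller of the two and lies beyond the usual scatter; its gap to compound 2 is wider and also beyond the scatter. On these three numbers compound 3 therefore stands as the most potent of the set, though all three are weak.

Compound 4, `CCN1CC(NC(=O)[C@@H]2CCCN(S(=O)(=O)c3ccc(S(=O)(=O)N(CC)CC)cc3)C2)C1`, is the next step from compound 3. The change is (1-ethylazetidin-3-yl)amino in place of isopropyl(methyl)amino on a carbonyl carbon; the same difference, cut one bond further out, reads isopropyl(methyl)carbamoyl to (1-ethylazetidin-3-yl)carbamoyl. Among the measured compounds shown here, no pair of measured compounds shares this change, so there is no measured step to lean on; the expectation rests only on compound 3 and its value 7700 nM as the starting point.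

The step from compound 3 to compound 4 is expected to be small, a 1.3-fold higher number from compound 3 to compound 4 (0.11 log units; within the scatter), likely within the scatter or at most a modest weakening. Compound 4 is estimated at 10000 nM in this assay, with a range from 3000 nM to 35000 nM.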

Compound 4, half-maximal inhibitory concentration: > 30000 nM
Compound 4 was reported as a limit (the forecaster's own chance of this, stated with the estimate: 15%); middle value at least 3.0-fold (0.47 log units) away from the limit.
By their numbers in this assay, from the lowest: compound 3; then compounds 1 and 2 (each within the scatter of the next). At a limit, above all of these: compound 4.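

In this assay compound 4 is reported only as a limit, > 30000 nM. The earlier compounds shown here gave no step at this place, and the first one read here, (1-ethylazetidin-3-yl)amino in place of isopropyl(methyl)amino on a carbonyl carbon, is an at least 3.8-fold higher number from compound 3 to compound 4 (0.59 log units; beyond the scatter), so the group carried on this carbonyl carbon does matter to the read-out, and this replacement goes the wrong way. The step has only a lower bound and its full size stays unknown, because the reading for compound 4 ends at a limit: the limit of > 30000 nM in this assay, at which 1 of the 4 values shown sits.

As far as these compounds go, the change brings in the four-membered ring, its ring nitrogen with the ethyl group, and the amide hydrogen all at once, and this single step cannot separate them, so which of these goes with the loss remains open. Also open, from the compounds shown here alone, is how a simpler group on the same carbonyl carbon, such as isopropylamino or a dimethylamino group, would read, and whether any group there improves on compound 3 at 7700 nM.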